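Ether series on J774 cells: notes toward compound 4

The source may hold more compounds than are shown below. What is called first, only, known or untested is meant among the compounds shown, and "the series" means these compounds.

Measured so far in an ADME assay on J774 cells (Mus musculus) for cytotoxicity, read by MTT assay, with a stated time of 24 h, tested at 30 uM; a lower number here means a stronger effect, a higher number a weaker effect of the compound at the concentration tested:
- compound 1 `CCCCCCCCCCCO[C@@H]1[C@@H](N)[C@@H](O[C@H]2[C@H](O)[C@@H](OCCCCCCC)[C@H](N)C[C@@H]2N)O[C@H](CN)[C@H]1O` gives 39.1%
- compound 2 `CCCCCCCCCO[C@@H]1[C@@H](N)[C@@H](O[C@H]2[C@H](O)[C@@H](O)[C@H](N)C[C@@H]2N)O[C@H](CN)[C@H]1OCCCCCCCCC` gives 48.6%
- compound 3 `CCCCCCCCCO[C@@H]1[C@@H](N)[C@@H](O[C@H]2[C@H](O)[C@@H](OCCCCCCCCC)[C@H](N)C[C@@H]2N)O[C@H](CN)[C@H]1O` gives 67.4%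

Compound 1 gives the lowest of the three numbers in this assay. Its gap to compound 2 is within the usual scatter of the measurement, so the two cannot be set apart; its gap to compound 3 is beyond the scatter, and compound 3 therefore shows the weaker effect of the pair. Within the data shown here, no single-point step between measured compounds is available, so the size that one change in the chain pattern brings in this assay is not known from the data.

Compound 4 `CCCCCCCCCCCO[C@@H]1[C@@H](N)[C@@H](O[C@H]2[C@H](O)[C@@H](O)[C@H](N)C[C@@H]2N)O[C@H](CN)[C@H]1O` is compound 1 with one change: hydrogen in place of heptyl on an oxygen on a saturated carbon. The undecyl chain of compound 1 stays; the heptyl is gone.

The expectation rests on little. The compounds carrying two chains give the lower numbers here, and compound 4 carries only one, so a step toward a higher number in this assay is expected for compound 4, of moderate size and possibly reaching beyond the scatter: a number 20.9 percentage points higher from compound 1 to compound 4 (beyond the scatter). For compound 4 the estimated value in this assay is 60%, within a range from 42% to 82%.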

Compound 4, a percentage reported as activity, at one concentration (the size of the read-out at that concentration, not a potency): 77.1%
Compound 4: the middle estimate sits 17.1 percentage points below what was measured; the measured number falls inside the stated range.
By their numbers in this assay, from the lowest: compounds 1 and 2 (each within the scatter of the next); then compounds 3 and 4 (each within the scatter of the next).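

In this assay, hydrogen in place of heptyl on an oxygen on a saturated carbon, with the undecyl chain kept, gives a number 38 percentage points higher from compound 1 to compound 4 (beyond the scatter). For this pair, the heptyl at this place accounts for a large part of the effect at the tested concentration: with the undecyl chain as its only chain, compound 4 gives 77.1%, so that chain alone does not reproduce the stronger effect seen with both chains present, and this reading rests on one pair only. Nothing at hand explains the size of this step or says what lies behind it.

Still open, as far as these compounds go, is how the read-out depends on the group at this oxygen: whether a short chain such as methyl, a longer chain such as dodecyl, or an amine in place of heptyloxy would keep the effect, lose it or land somewhere in between. Also open, from the compounds shown here alone, is whether removing a chain at this place brings a step of similar size when the remaining chain is other than undecyl, for instance nonyl or tridecyl.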